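The compounds below may be only part of what the source reports. "The series", "measured", "known", "first", "only" and "open" are said of these compounds alone.

Of the compounds shown here, three built on a shared core have so far been tested in an ADME assay on A549 cells (Homo sapiens) for cytotoxicity, read by resazurin assay, with a stated time of 48 h; on this read-out higher numbers stand for lower toxicity in this test and lower numbers for higher toxicity in this test. Compound 1 `CCCCCCC(C)Nc1ccc(NC(=O)c2cc(Cl)ccc2O)c(Cl)c1` gives 23500 nM in this assay, the second highest of the three numbers. Compound 2 `O=C(Nc1ccc(N(CC2CC2)CC2CC2)cc1Cl)c1cc(Cl)ccc1O` gives 12800 nM, and compound 3 `O=C(Nc1ccc(NCc2ccc(O)nc2)cc1Cl)c1cc(Cl)ccc1O` gives 98500 nM. The step of a 1.8-fold lower number from compound 1 to compound 2 (0.26 log units; within the scatter) lies within the scatter, whereas a 4.2-fold higher number from compound 1 to compound 3 (0.62 log units; beyond the scatter) and a 7.7-fold higher number from compound 2 to compound 3 (0.89 log units; beyond the scatter) lie beyond it, so compound 3 carries the highest number of the three.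

Compound 4 `CC(C)(CCO)Nc1ccc(NC(=O)c2cc(Cl)ccc2O)c(Cl)c1` has not yet been tested in this assay. It differs from compound 1 in one place: 3-hydroxy-1,1-dimethylpropyl in place of 1-methylheptyl on a nitrogen on an aromatic ring. The step from compound 1 to compound 3 bears most directly on this change, since there too the 1-methylheptyl group on the same nitrogen gave way to a group carrying a hydroxy, and the number rose modestly. The step from compound 1 to compound 2, where the nitrogen instead received two cyclopropylmethyl groups, stayed within the scatter. A modest rise is therefore expected for compound 4, probably smaller than that seen with compound 3, with a step of a 1.9-fold higher number from compound 1 to compound 4 (0.28 log units; within the scatter). Compound 4 is estimated to give 45000 nM in this assay, in a range from 18000 nM to 110000 nM.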

Compound 4, half-maximal cytotoxic concentration: 170000 nM
The estimate for compound 4 lay 3.8-fold (0.58 log units) below the measured number; the whole stated range lies below it.
By their numbers in this assay, from the lowest: compounds 2 and 1 (each within the scatter of the next); then compounds 3 and 4 (each within the scatter of the next).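

In this assay, the exchange of 1-methylheptyl for 3-hydroxy-1,1-dimethylpropyl on this nitrogen gives a 7.2-fold higher number from compound 1 to compound 4 (0.86 log units; beyond the scatter), which shows that the number at this position can rise with an entering group that has no ring. The step of a 1.7-fold higher number from compound 3 to compound 4 (0.24 log units; within the scatter) puts the two hydroxy-bearing compounds together, although one group holds a ring and the other is an open chain, while a 13-fold higher number from compound 2 to compound 4 (1.12 log units; beyond the scatter) is the largest step in the set, and among these four compounds neither of the two without a hydroxy reaches the numbers of the two with one, with no compound going against this. Nothing available here gives a measured reason for these differences.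

The compounds shown leave open whether the higher number goes with the hydroxy itself or with the rest of the 3-hydroxy-1,1-dimethylpropyl chain, since the two change together from compound 1 to compound 4. A 1,1-dimethylbutyl group with no hydroxy, or the same branched chain ending in a methoxy, an amine or a carboxylic acid, would bear on that question.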